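The compounds below may be only part of what the source reports. "The series", "measured", "known", "first", "only" and "open" are said of these compounds alone.

Measured so far:
- compound 1, `Cc1cc(/C=C2\SC(=S)N(Cc3ccc(Br)cc3)C2=O)c(C)n1-c1ccc(O)c(C(=O)O)c1`: 94400 nM
- compound 2, `COc1ccc(CN2C(=O)/C(=C/c3cc(C)n(-c4ccc(O)c(C(=O)O)c4)c3C)SC2=S)cc1`: 75300 nM

In an ADME assay on MT2 cells (Homo sapiens) for cytotoxicity, read by XTT assay, with a stated time of 4 days (on this read-out lower numbers stand for higher toxicity in this test and higher numbers for lower toxicity in this test), compound 1 gives 94400 nM. Compound 2 gives 75300 nM, and the step of a 1.3-fold lower number from compound 1 to compound 2 (0.10 log units; within the scatter) is the only comparison available; it lies within the scatter, so compound 1 is not separated from compound 2 on the numbers shown, and no ordering between the two can be read.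

Compound 3, `Cc1cc(/C=C2\SC(=S)N(Cc3ccc(C(C)(C)C)cc3)C2=O)c(C)n1-c1ccc(O)c(C(=O)O)c1`, is not yet measured. It differs from compound 1 as follows: tert-butyl in place of bromo on an aromatic carbon. Going by the values given here, the one measured step that bears on this change is the exchange at the same aromatic carbon from compound 1 to compound 2, a 1.3-fold lower number from compound 1 to compound 2 (0.10 log units; within the scatter), which stayed within the scatter. Nothing measured here distinguishes one substituent at this carbon from another, so no step beyond the scatter is expected in this assay in either direction.

The step from compound 1 to compound 3 is therefore expected to be a 1.0-fold lower number from compound 1 to compound 3 (0.02 log units; within the scatter). Compound 3 is estimated at 90000 nM in this assay, with a range from 45000 nM to 180000 nM.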

Compound 3, half-maximal cytotoxic concentration: 55200 nM
Estimate against measurement, compound 3: 1.6-fold (0.21 log units) above, within the range that was stated.
By their numbers in this assay, from the lowest: compounds 3, 2 and 1 (each within the scatter of the next).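

In this assay the aromatic carbon para to a large group now carries a third substituent, and tert-butyl, with 4 heavy atoms where bromo has 1, gives a 1.7-fold lower number from compound 1 to compound 3 (0.23 log units; within the scatter) and a 1.4-fold lower number from compound 2 to compound 3 (0.13 log units; within the scatter) with neither step leaving the scatter. The earlier compounds shown here offered a single comparison at this carbon, bromo against methoxy; there are now three pairs among bromo, methoxy and tert-butyl, and none of them is separated, so for these three compounds the number does not distinguish the substituent, even with the larger group in place. No measurement is available that bears on the reason for this result.

As far as these compounds go, whether an amine or a carboxylic acid on this carbon, or a longer chain in the place of tert-butyl, would give a step beyond the scatter remains open. Also open is whether changes elsewhere on the shared core would behave in the same way, as the three compounds shown differ from one another in this one place only.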